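The source may report more compounds than this note shows. Statements on the series, on what has been measured and on what is new or still open speak of the compounds shown alone.

In an assay on HeLa cells for inhibition of sphingosine-1-phosphate transporter SPNS2 (Mus musculus), read by LC-MS, tested at 2 uM (a higher number here means more inhibition at the concentration tested (going by the name of the read-out), a lower number less inhibition), three compounds have been measured:
compound 1 `CCCCCCCCCCc1ccc(-c2noc([C@@H]3CCCN3)n2)cc1`, 21%;
compound 2 `CCCCCCCCCCc1ccc(-c2noc(-c3cccc(CN)c3)n2)cc1`, 2%;
compound 3 `CCCCCCCCCCc1ccc(-c2noc(CC(O)CN)n2)cc1`, 59%.

Compound 3 stands highest of the three: nearest is compound 1, a number 38 percentage points higher from compound 1 to compound 3 (beyond the scatter), furthest is compound 2, a number 57 percentage points higher from compound 2 to compound 3 (beyond the scatter). Compound 4 `CCCCCCCCCCc1ccc(-c2noc([C@H](N)CCCCN)n2)cc1` differs from compound 3 in one place: 1,5-diaminopentyl in place of 3-amino-2-hydroxypropyl on an aromatic carbon. For the measured compounds named here, no measured step exchanges one acyclic amino chain for another. Going by the values given here, the steps that bear on it, a number 38 percentage points higher from compound 1 to compound 3 (beyond the scatter) and a number 57 percentage points higher from compound 2 to compound 3 (beyond the scatter), both rose strongly when an acyclic amino chain replaced a ring-bearing group, while a number 19 percentage points lower from compound 1 to compound 2 (beyond the scatter) was only modest. Since compound 4 keeps an acyclic chain with two nitrogens, a step near the scatter or a small fall is expected. Compound 4 is estimated at 50%, ranging from 25% to 75%. The expected step is a number 9 percentage points lower from compound 3 to compound 4 (within the scatter).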

Compound 4, a percentage reported as inhibition, at one concentration (the size of the read-out at that concentration, not a potency): 50%
Compound 4: middle estimate and measured number agree at the digits printed; low and high end bracket the measured number.
By their numbers in this assay, from the lowest: compound 2; then compound 1; then compounds 4 and 3 (each within the scatter of the next).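

At this position on the five-membered aromatic ring, the 1,5-diaminopentyl group stands level with the 3-amino-2-hydroxypropyl group, with a number 9 percentage points lower from compound 3 to compound 4 (within the scatter) as the step, so among these acyclic amino chains the hydroxyl is not required and a larger chain with a second nitrogen is accepted. The same group also clears both ring-bearing groups, with a number 48 percentage points higher from compound 2 to compound 4 (beyond the scatter) and a number 29 percentage points higher from compound 1 to compound 4 (beyond the scatter) as the steps, so compound 3 is not alone among the acyclic chains in doing so. No measurement here explains these differences.

Still open, as far as these compounds go, is whether a plain aminopropyl chain, with one amine and no hydroxyl, would match them, and whether a carboxylic acid could replace the terminal amine.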